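Swapping the aryl substituent on the shared core: an expectation

This account rests on a few compounds, and the source may have more. Where it says the series, first, only, none or still open, it means among the compounds named here.

The series shares one core, decorated with a dimethylaminobutyl carbamate on a benzyl group and an aryl ring on the aromatic carbon of the fused ring system. In an ADME assay on Huh-7 cells (Homo sapiens) for cytotoxicity, read by MTT assay, with a stated time of 48 h (a lower number here means that less compound is tolerated, a higher number that more compound is tolerated), compound 2 `CN(C)CCCCOC(=O)Nc1ccc(Cn2nc(-c3cccc(C#N)c3)c3ccccc3c2=O)cc1` gives 17200 nM. Going by the values given here, its only measured neighbour is compound 1 `COc1ccc(-c2nn(Cc3ccc(NC(=O)OCCCCN(C)C)cc3)c(=O)c3ccccc23)cc1`, which in this assay gives 20300 nM; the two numbers sit within the scatter of each other, so neither can be called better tolerated than the other.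

Compound 3 `CN(C)CCCCOC(=O)Nc1ccc(Cn2nc(-c3ccccc3F)c3ccccc3c2=O)cc1` has not been measured. It differs from compound 2 in one place: 2-fluorophenyl in place of 3-cyanophenyl on an aromatic carbon.

Among the compounds with values here, the only step that bears on an aryl swap at this position is a 1.2-fold lower number from compound 1 to compound 2 (0.07 log units; within the scatter), and it stayed within the scatter. No other change at this carbon has been measured, so nothing in hand points to a direction. The expected step in this assay from compound 2 to compound 3 is therefore a 1.0-fold higher number from compound 2 to compound 3 (0.02 log units; within the scatter), none beyond the scatter. For compound 3 the estimate in this assay is 18000 nM, with a range from 8000 nM to 40000 nM.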

Compound 3, half-maximal cytotoxic concentration: 52500 nM
Compound 3: the middle estimate sits 2.9-fold (0.46 log units) below what was measured; the whole stated range lies below it.
By their numbers in this assay, from the lowest: compounds 2 and 1 (each within the scatter of the next); then compound 3.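

In this assay the replacement of 3-cyanophenyl by 2-fluorophenyl on this aromatic carbon gives a 3.1-fold higher number from compound 2 to compound 3 (0.48 log units; beyond the scatter) and the replacement of 4-methoxyphenyl by 2-fluorophenyl gives a 2.6-fold higher number from compound 1 to compound 3 (0.41 log units; beyond the scatter) as well, so both steps are modest but lie beyond the scatter. The earlier pair had shown no separation at this position, whereas the new compound shows that an aryl swap here can move the tolerated concentration upward, with 2-fluorophenyl standing apart from the two aryl groups that remain within the scatter of each other. Nothing available accounts for this difference.

The three compounds do not separate the effect of having fluorine on the ring from that of where it sits, so plain phenyl, 3-fluorophenyl and 4-fluorophenyl would each be informative at this carbon, as would 2-chlorophenyl or 2-methylphenyl. Going by these compounds, it also remains open whether the same rise would hold with a shorter chain in place of the dimethylaminobutyl carbamate, since all three compounds carry that group unchanged.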